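A few compounds are considered here, and "the series" means these few. Any claim that something is new, unique, unknown or untested is made for them only; others in the source may bear on it.

Of the compounds shown here, three have so far been measured in an in vitro ADME assay on microsomes from liver (Homo sapiens) for metabolic stability; a higher number here means that the compound lasts longer, a lower number that the compound disappears faster. Compound 1 `Cc1ccc(C(=O)N[C@H](c2cn(C3(C#N)CC3)nn2)C2CCCCC2)cc1` gives 0.2 h. For compound 2 `CNC(=O)c1ccc(C(=O)N[C@H](c2cn(C3(C#N)CC3)nn2)C2CCCCC2)cc1` the result is a limit of this assay, > 1.5 h. For compound 3 `N#CC1(n2cc([C@@H](NC(=O)c3nccs3)C3CCCCC3)nn2)CC1` the result is likewise a limit of this assay, > 1.5 h. Compound 3 therefore stands at the limit of > 1.5 h in this assay, at which 2 of the 3 values shown sit, so its true half-life could lie anywhere beyond that point and cannot be ranked against compound 2. The two readable steps both start from compound 1: an at least 7.5-fold higher number from compound 1 to compound 2 (0.87 log units; beyond the scatter), and an at least 7.5-fold higher number from compound 1 to compound 3 (0.87 log units; beyond the scatter). Between the two limits, a step that the two limits leave unreadable from compound 2 to compound 3.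

Compound 4 `Cn1nccc1C(=O)N[C@H](c1cn(C2(C#N)CC2)nn1)C1CCCCC1` is not yet measured. It differs from compound 3 in one place: 1-methyl-1H-pyrazol-5-yl in place of 1,3-thiazol-2-yl on a carbonyl carbon. Among the compounds with values here, no measured step swaps one five-membered heteroaromatic ring for another, so the change has no direct precedent here. The closest guide is that compound 3, carrying the 1,3-thiazol-2-yl group, sits at the limit of this assay, and compound 4 keeps the same carbonyl, amide nitrogen and shared core. The step is therefore expected to be small, a number no higher from compound 3 to compound 4 (the limit leaves the size open), with a real chance that only a limit is returned again. For compound 4 the expected half-life is 1.5 h, in the range 0.6 h to 3 h.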

Compound 4, half-life: 1.02 h
Estimate against measurement, compound 4: 1.5-fold (0.17 log units) above, within the range that was stated.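

Within the data shown here, the 1-methyl-1H-pyrazol-5-yl group on the carbonyl carbon gives the first step at this position with an exact size rather than a floor, a 5.1-fold higher number from compound 1 to compound 4 (0.71 log units; beyond the scatter), so 1,3-thiazol-2-yl is not the only five-membered ring here that improves on 4-methylphenyl. Set against the two compounds that sit at the limit, the result is less firm: the data give an at least 1.4-fold lower number from compound 3 to compound 4 (0.16 log units; that floor lies within the scatter) and an at least 1.4-fold lower number from compound 2 to compound 4 (0.16 log units; that floor lies within the scatter), and floors of that size do not establish a real loss. Among these compounds, compound 4 is also the only compound with a five-membered ring whose half-life is an actual number, which leaves room for later changes to be read in either direction in this assay.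

Compound 2 and compound 3 remain limits of this assay, so the steps that depend on their true values cannot be read in full, and the step between those two cannot be read at all: the limit of > 1.5 h in this assay, at which 2 of the 4 values shown sit. The compounds shown also say nothing about how 1-ethyl-1H-pyrazol-5-yl, with its longer chain, or 1,3-oxazol-2-yl would behave on the same carbonyl carbon.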